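Dimethylamino step at the assay limit

The compounds below may be only part of what the source reports. "The series", "measured", "known", "first", "only" and "open" are said of these compounds alone.

Values in a functional assay on L02 cells (Homo sapiens) for inhibition, read by Griess assay, with stated times of 1 h and 24 h; a higher number here means a weaker inhibitor, a lower number a stronger inhibitor:
Compound 1 `CCCc1nn(C)c2c(NC(C)C)nc(/C=C/c3ccc[n+]([O-])c3)nc12`: 324000 nM
Compound 2 `CC(C)Nc1nc(/C=C/c2ccccc2)nc2ccsc12`: > 1000000 nM, a limit of the assay
Compound 3 `CNc1nc(/C=C/c2ccccc2)nc2ccsc12`: > 1000000 nM, a limit of the assay

Compound 1 alone has a measured number, and its core differs from the shared core of the other two compounds. Compound 3 has no number, only the limit > 1000000 nM. It stands at the limit of > 1000000 nM in this assay, at which 2 of the 3 values shown sit.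

Compound 4 `CN(C)c1nc(/C=C/c2ccccc2)nc2ccsc12` has methyl in place of hydrogen on a nitrogen on an aromatic ring, which turns methylamino into dimethylamino: methyl in place of hydrogen on a nitrogen on an aromatic ring.

For the measured compounds named here, the one measured step bearing on this change is a step that the two limits leave unreadable from compound 2 to compound 3, which also alters a group on a nitrogen on an aromatic ring. Given a step that the two limits leave unreadable from compound 2 to compound 3, no size or direction of step can be expected in this assay from the measured data. The working expectation is that compound 4 also reads out only as a limit, without a number. Any number that does appear would be hard to set against compound 3, which offers only a limit for comparison.

An estimated a number no higher from compound 3 to compound 4 (the limit leaves the size open) is carried forward on that basis. The expected value for compound 4 is 1000000 nM, with an estimated range from 400000 nM to 3000000 nM.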

Compound 4, half-maximal inhibitory concentration: > 1000000 nM
Compound 4 was reported as a limit (the forecaster's own chance of this, stated with the estimate: 80%); the middle value sits exactly at the limit.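

For the compounds shown here, compound 2, compound 3 and compound 4 all stand as limits of the assay in this assay and not as numbers, so no step among them can be read. Left open is how the amino groups on the shared core rank against one another, and how they compare with compound 1, whose 324000 nM is the only measured number shown.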